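Shortening the link to the aminocyclohexyl amine

This account rests on a few compounds, and the source may have more. Where it says the series, first, only, none or still open, it means among the compounds named here.

Among the measured compounds shown here, compound 1 `N[C@H]1CC[C@H](CN(C[C@H]2Cc3ccccc3CN2)[C@H]2CCCc3cccnc32)CC1` gives 39% in an ADME assay on microsomes from liver (Homo sapiens) for metabolic stability (a lower number here means that less of the compound is left, a higher number that more of the compound is left), the lowest of the two numbers known. For the measured compounds named here, compound 2 `C/C(CN)=C(\F)CN(C[C@H]1Cc2ccccc2CN1)[C@H]1CCCc2cccnc21` stands far higher, with 100% in this assay; the one recorded step, a number 61 percentage points higher from compound 1 to compound 2 (beyond the scatter), replaces the whole cyclohexyl group. Compound 3 `N[C@H]1CC[C@H](N(C[C@H]2Cc3ccccc3CN2)[C@H]2CCCc3cccnc32)CC1` keeps that group and changes only its link: 4-aminocyclohexyl in place of (4-aminocyclohexyl)methyl on an amine nitrogen. Going by the values given here, no measured step bears directly on this smaller change, so a step no larger than the scatter is expected, a number 6 percentage points higher from compound 1 to compound 3 (within the scatter). Compound 3 is therefore estimated at 45%, within 20% to 75%.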

Compound 3, percent of the compound remaining: 95%
The estimate for compound 3 lay 50 percentage points below the measured number; the whole stated range lies below it.
By their numbers in this assay, from the lowest: compound 1; then compounds 3 and 2 (each within the scatter of the next).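

With the cyclohexyl ring kept, 4-aminocyclohexyl in place of (4-aminocyclohexyl)methyl on the amine nitrogen gives a number 56 percentage points higher from compound 1 to compound 3 (beyond the scatter) in this assay, so this single change is enough and the ring need not be replaced. The step of a number 5 percentage points lower from compound 2 to compound 3 (within the scatter) shows that 4-aminocyclohexyl and 3-(aminomethyl)-2-fluorobut-2-en-1-yl cannot be told apart in this assay at this position. No evidence is available to explain the large step. The compounds shown leave open how a longer chain on the amine nitrogen would read, and whether a hydroxyl group could stand in place of the amine on the cyclohexyl ring.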